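Arginase-1 series: amine-bearing substituents on the ring nitrogen

The compounds below may be only part of what the source reports. "The series", "measured", "known", "first", "only" and "open" are said of these compounds alone.

Measured compounds:
Compound 1 `N[C@@]1(C(=O)O)CN(Cc2ccncc2)C[C@@H]1CCCB(O)O` gives 600 nM in an assay for inhibition of arginase-1 (Homo sapiens), read by colorimetric assay, with a stated time of 60 min, in the presence of a further agent that is not named here; a lower number here means a stronger inhibitor, a higher number a weaker inhibitor.
Compound 2 `Cc1nn(C)c(C)c1CN1C[C@H](CCCB(O)O)[C@](N)(C(=O)O)C1` gives 340 nM in this assay.
Compound 3 `C[C@@H](N)CN1C[C@H](CCCB(O)O)[C@](N)(C(=O)O)C1` gives 16 nM in this assay.

Compound 3 holds the lowest number of the three. Its nearest neighbour is compound 2 (a 21-fold lower number from compound 2 to compound 3 (1.33 log units; beyond the scatter)), and compound 1 lies further off (a 38-fold lower number from compound 1 to compound 3 (1.57 log units; beyond the scatter)). The two aromatic substituents sit close to each other (a 1.8-fold lower number from compound 1 to compound 2 (0.25 log units; within the scatter)).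

Compound 4 `N[C@@]1(C(=O)O)CN(C[C@@H]2COCCN2)C[C@@H]1CCCB(O)O` is not yet measured. It differs from compound 3 as follows: a group of 6 heavy atoms (4 carbon, 1 nitrogen, 1 oxygen; one six-membered non-aromatic ring with 2 hetero atoms) in place of a group of 3 heavy atoms (2 carbon, 1 nitrogen; no ring), on a saturated chain carbon bound to an amine nitrogen in a ring. Both steps into compound 3 bear on this change, since each replaced a ring substituent with the 1-aminoethyl group and each was large. The entering group keeps a hydrogen-bond donor and a nitrogen, but within a six-membered non-aromatic ring rather than an open chain, so part of the gain seen in compound 3 is expected to be kept rather than all of it. Compound 4 is therefore expected to give 60 nM (range 15 nM to 250 nM) in this assay, a step of a 3.8-fold higher number from compound 3 to compound 4 (0.57 log units; beyond the scatter), modest and perhaps near the scatter, with compound 4 expected to stay well clear of compound 1 and compound 2.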

Compound 4, half-maximal inhibitory concentration: 10 nM
Beside the measured number, compound 4's estimate is 6.0-fold (0.78 log units) above it; measured number outside the range, below it.
By their numbers in this assay, from the lowest: compounds 4 and 3 (each within the scatter of the next); then compounds 2 and 1 (each within the scatter of the next).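

In this assay the entering six-membered non-aromatic ring with 2 hetero atoms, on a saturated chain carbon bound to an amine nitrogen in a ring, cannot be told apart from 1-aminoethyl, with a 1.6-fold lower number from compound 3 to compound 4 (0.20 log units; within the scatter) as the step. An open chain is therefore not required at this place, and the large separation from the aromatic substituents persists in compound 4, with a 34-fold lower number from compound 2 to compound 4 (1.53 log units; beyond the scatter) and a 60-fold lower number from compound 1 to compound 4 (1.78 log units; beyond the scatter) as the steps. No data here bear on the reason for either finding.

Still open, on these data alone, is whether the ring oxygen of compound 4 counts, which a piperidine ring with carbon in its place would address. A methyl group on the ring nitrogen would likewise address the role of the amine hydrogen.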